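Amide substitution and paw edema inhibition: compound 4

This account rests on a few compounds, and the source may have more. Where it says the series, first, only, none or still open, it means among the compounds named here.

Measured compounds in a functional assay on the whole organism for inhibition, with Rattus norvegicus as the target, read by paw edema, with stated times of 30 min and 5 h, at a dose of 0.28 mmol/kg by the oral route; a lower number here means less inhibition, a higher number more inhibition at the dose given (going by the name of the read-out):
compound 1 `COc1ccc(-n2nc(C(N)=O)nc2-c2cc(OC)c(OC)c(OC)c2)cc1` gives 64%
compound 2 `CCNC(=O)c1nc(-c2cc(OC)c(OC)c(OC)c2)n(-c2ccc(OC)cc2)n1` gives 52%
compound 3 `COc1ccc(-n2nc(C(=O)Nc3ccccc3OC)nc2-c2cc(OC)c(OC)c(OC)c2)cc1` gives 10%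

Among these three, compound 1 stands highest, with compound 2 nearest, a step of a number 12 percentage points lower from compound 1 to compound 2 (beyond the scatter), and compound 3 furthest, a step of a number 54 percentage points lower from compound 1 to compound 3 (beyond the scatter). Compound 4 `COc1ccc(-n2nc(C(=O)Nc3ccc(C(=O)O)cc3)nc2-c2cc(OC)c(OC)c(OC)c2)cc1` has not yet been measured. It differs from compound 1 in one place: 4-carboxyphenyl in place of hydrogen on an amide-type nitrogen.

Among the compounds with values here, two measured steps bear on this change. Replacing the amide hydrogen of compound 1 by ethyl gave a modest fall, a number 12 percentage points lower from compound 1 to compound 2 (beyond the scatter), while replacing it by 2-methoxyphenyl gave a large fall, a number 54 percentage points lower from compound 1 to compound 3 (beyond the scatter); moving from ethyl to that aryl group likewise fell, a number 42 percentage points lower from compound 2 to compound 3 (beyond the scatter). Compound 4 also carries an aryl group on that nitrogen, so a large downward step in this assay is expected, a number 42 percentage points lower from compound 1 to compound 4 (beyond the scatter). Whether the carboxylic acid on the ring alters this cannot be told from the measured compounds. Compound 4 is therefore estimated at 22%, within a range of 0% to 48%.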

Compound 4, a percentage reported as inhibition, in the whole organism at one dose (the size of the read-out at that dose, not a potency): 60%
Beside the measured number, compound 4's estimate is 38 percentage points below it; measured number outside the range, above it.
By their numbers in this assay, from the lowest: compound 3; then compounds 2, 4 and 1 (each within the scatter of the next, the first and the last beyond it).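

On the amide-type nitrogen, an aromatic ring does not by itself bring a large loss in this assay: with 4-carboxyphenyl in place of the amide hydrogen the change is a number 4 percentage points lower from compound 1 to compound 4 (within the scatter), and against ethyl it is a number 8 percentage points higher from compound 2 to compound 4 (within the scatter). What the ring carries, or where it carries it, therefore matters greatly, as exchanging 2-methoxyphenyl for 4-carboxyphenyl gives a number 50 percentage points higher from compound 3 to compound 4 (beyond the scatter). No measurement at hand explains this difference.

The two aromatic groups differ both in the substituent and in its place on the ring, so the compounds shown cannot separate those two changes. A plain phenyl group or the methyl ester of the carboxylic acid on the same nitrogen would show whether the carboxylic acid itself is what counts.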